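This account rests on a few compounds, and the source may have more. Where it says the series, first, only, none or still open, it means among the compounds named here.

In a functional assay on Jurkat cells (Homo sapiens) for cytotoxicity, read by MTT assay, with a stated time of 72 h (on this read-out lower numbers stand for stronger inhibition and higher numbers for weaker inhibition), compound 1 (`CCOC(=O)c1sc2ccccc2c1Nc1cc(OC)c(OC)c(OC)c1`) gives 3020 nM and compound 2 (`COC(=O)c1sc2nc(C)ccc2c1Nc1cc(OC)c(OC)c(OC)c1`) gives 0.6 nM as the lower of the two numbers, a gap well beyond the scatter. Among the compounds with values here, no measured step changes a single place, so any expectation rests on compound 2 and the structural change alone. Compound 3 (`COC(=O)c1sc2ncccc2c1Nc1cc(OC)c(OC)c(OC)c1`) departs from compound 2 in one place: hydrogen in place of methyl on an aromatic carbon with hydrogen in place of methyl on an aromatic carbon, next to the ring nitrogen. In this assay a moderate rise in the number is expected, meaning weaker inhibition, since compound 2 at 0.6 nM already stands low and leaves more room upward than downward. The estimated change is a 6.7-fold higher number from compound 2 to compound 3 (0.82 log units; beyond the scatter) and may only just clear the scatter. Compound 3 is expected at 4 nM with an estimated range from 0.6 nM to 40 nM in this measurement.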

Compound 3, half-maximal inhibitory concentration: 1110 nM
Beside the measured number, compound 3's estimate is 280-fold (2.44 log units) below it; the measured number lies above the stated range.
By their numbers in this assay, from the lowest: compound 2; then compound 3; then compound 1.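

Read in this assay the methyl on the aromatic carbon next to the ring nitrogen turns out to matter greatly: putting hydrogen in its place gives a 1900-fold higher number from compound 2 to compound 3 (3.27 log units; beyond the scatter) and is the first change in a single place that can be read here. With all else in compound 2 held the same, this one carbon separates a number near the low end of those shown from a far higher one. Nothing available gives a reason for the size of this step.

The compounds shown do not tell whether this low number belongs to methyl alone or would also be kept by an ethyl, a methoxy group, a chlorine or an amine on the same carbon. They also leave open whether the same step would be as large with the ethyl ester in place of the methyl ester.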